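The source may report more compounds than this note shows. Statements on the series, on what has been measured and on what is new or still open speak of the compounds shown alone.

The measured compounds and their values in a functional assay on SW480 cells (Homo sapiens) for cytotoxicity, read by MTT assay, with a stated time of 24 h (on this read-out lower numbers stand for stronger inhibition and higher numbers for weaker inhibition), are as follows. Compound 1 `C=CC1=C(C(=O)NCc2ccccc2)C(c2ccc(OC)c(OC)c2)OC1` gives a limit of the assay, > 100000 nM. Compound 2 `C=CC1=C(C(=O)NCc2ccccc2)C(c2ccc(OC)cc2)OC1` gives 39500 nM. Compound 3 `C=CC1=C(C(=O)NC2CCCCC2)C(c2ccc(F)cc2)OC1` gives a limit of the assay, > 100000 nM.

Compound 2 thus holds the only number shown; the other two values are limits, as the limit of > 100000 nM in this assay, at which 2 of the 3 values shown sit, records. Going by the values given here, the one measured step, an at least 2.5-fold lower number from compound 1 to compound 2 (0.40 log units; beyond the scatter), concerns a methoxy on an aromatic carbon and not the amide nitrogen. Compound 4 `C=CC1=C(C(=O)Nc2ccccc2OC)C(c2ccc(OC)cc2)OC1` differs from compound 2 by 2-methoxyphenyl in place of benzyl on an amide-type nitrogen. Among the compounds with values here, no measured step touches that position, so the change is untested here; compound 3 carries a different group on the nitrogen but differs from compound 2 in two places. Compound 4 is therefore expected to show no step beyond the scatter, a 1.3-fold higher number from compound 2 to compound 4 (0.10 log units; within the scatter). Compound 4 is estimated at 50000 nM, within 15000 nM to 100000 nM.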

Compound 4, half-maximal inhibitory concentration: > 100000 nM
Compound 4 was reported as a limit (the forecaster's own chance of this, stated with the estimate: 40%); middle value at least 2.0-fold (0.30 log units) away from the limit.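

Going by these compounds alone, the amide nitrogen, which no earlier step had touched, proves sensitive in this assay: 2-methoxyphenyl in place of benzyl gives an at least 2.5-fold higher number from compound 2 to compound 4 (0.40 log units; beyond the scatter). The value of compound 4 is a limit, so this step fixes only a minimum size, and compound 2 remains the only compound with a number: the limit of > 100000 nM in this assay, at which 3 of the 4 values shown sit.

The compounds shown leave open whether the loss belongs to the methoxy of the 2-methoxyphenyl group or to the replacement of benzyl as such. An unsubstituted phenyl or a phenethyl group on the same nitrogen would separate these two readings.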